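One group exchanged on the shared core

The compounds below may be only part of what the source reports. "The series", "measured", "known", "first", "only" and "open" are said of these compounds alone.

In a physicochemical assay for solubility, in phosphate buffer, at pH 7.4 (on this read-out higher numbers stand for higher solubility and lower numbers for lower solubility), compound 1 `CC(=O)N[C@@H]1CCC[C@H](C(=O)Nc2cc(-c3cnn4c3CCC4)c(Cl)cn2)C1` gives 160000 nM, and compound 2 `CC(=O)N[C@@H]1CCC[C@H](C(=O)Nc2cc(-c3cnn4c3COCC4)c(Cl)cn2)C1` gives 220000 nM, so the two stand within the scatter of each other. Compound 3 `CC(=O)N[C@@H]1CCC[C@H](C(=O)Nc2cc(-c3cnn4c3CN(C)CC4)c(Cl)cn2)C1` has not yet been measured. Its structure departs from that of compound 2 in one place: a group of 10 heavy atoms (7 carbon, 3 nitrogen; one five-membered aromatic ring with 2 hetero atoms, one six-membered non-aromatic ring with 2 hetero atoms) in place of a group of 9 heavy atoms (6 carbon, 2 nitrogen, 1 oxygen; one five-membered aromatic ring with 2 hetero atoms, one six-membered non-aromatic ring with 2 hetero atoms), on an aromatic carbon. The exchanged group sits on an aromatic carbon, ortho to a chloro group. Both versions carry one five-membered aromatic ring with 2 hetero atoms and one six-membered non-aromatic ring with 2 hetero atoms. Within the data shown here, only one measured step bears on this exchange, and it concerns a group at the same place: a 1.4-fold higher number from compound 1 to compound 2 (0.14 log units; within the scatter). Among the measured compounds shown here, no measured compound carries the group that enters here, so this single step is thin evidence. Resting on it, no step beyond the scatter is expected in this assay. The estimated step is a 1.1-fold higher number from compound 2 to compound 3 (0.04 log units; within the scatter). For compound 3 the estimate is 240000 nM, with an expected range from 120000 nM to 480000 nM.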

Compound 3, solubility: 870000 nM
The estimate for compound 3 lay 3.6-fold (0.56 log units) below the measured number; the measured number lies above the stated range.
By their numbers in this assay, from the lowest: compounds 1 and 2 (each within the scatter of the next); then compound 3.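

Among these compounds, at this place, on an aromatic carbon ortho to a chloro group, the one earlier exchange had stayed within the scatter, whereas the group of 10 heavy atoms now gives a 4.0-fold higher number from compound 2 to compound 3 (0.60 log units; beyond the scatter) and a 5.4-fold higher number from compound 1 to compound 3 (0.74 log units; beyond the scatter) in this assay. The read-out at this position therefore does respond to the choice of group, even though the earlier pair gave no sign of it. The step from compound 2 comes with no difference in the computed ring types, hydrogen-bond donors, hydrogen-bond acceptors or net charge, the groups differing in that the entering one has a nitrogen and an extra carbon where the leaving one has an oxygen, and nothing measured here accounts for the size of the step.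

The compounds shown leave open whether a secondary amine without the extra carbon, or an acetyl group on that same nitrogen, would stand with compound 3 or with compounds 1 and 2. They also leave open whether the same exchange would give a step of this size on a core with another group in place of the chloro group.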